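Cyano in Place of Methoxy on the Phenyl Ring

The source may report more compounds than this note shows. Statements on the series, on what has been measured and on what is new or still open speak of the compounds shown alone.

The measured compounds and their values:
compound 1, `CC1(C)[C@H]2CC[C@]1(C)N(Cc1cn(-c3cccc(Cl)c3)nn1)C(=O)C2`, 70 nM
compound 2, `COc1ccc(-n2cc(CN3C(=O)C[C@@H]4CC[C@@]3(C)C4(C)C)nn2)cc1`, 70 nM
compound 3, `CC1(C)[C@H]2CC[C@]1(C)N(Cc1cn(-c3ccccc3)nn1)C(=O)C2`, 50 nM

All three share one core and differ only in the group on the phenyl ring that sits on an aromatic nitrogen. In a functional assay on LoVo cells (Homo sapiens) for inhibition, read by MTT assay, with a stated time of 24 h (a higher number here means a weaker inhibitor, a lower number a stronger inhibitor), compound 2 gives 70 nM, the same number as compound 1, and the two stand together at the top of the three numbers; the step of no change at the digits printed from compound 1 to compound 2 (within the scatter) shows no change. The step of a 1.4-fold lower number from compound 2 to compound 3 (0.15 log units; within the scatter) is small and within the scatter, as is a 1.4-fold lower number from compound 1 to compound 3 (0.15 log units; within the scatter). Taken together, the three values lie within the scatter of one another.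

Compound 4, `CC1(C)[C@H]2CC[C@]1(C)N(Cc1cn(-c3ccc(C#N)cc3)nn1)C(=O)C2`, is the next member. It differs from compound 2 by cyano in place of methoxy on an aromatic carbon. The step that bears most directly on this is a 1.4-fold lower number from compound 2 to compound 3 (0.15 log units; within the scatter), which removed the methoxy group altogether without a change beyond the scatter, and the chloro-to-hydrogen step a 1.4-fold lower number from compound 1 to compound 3 (0.15 log units; within the scatter) tells the same story for a different substituent on the same ring. Nothing seen here suggests that a change at this position moves this assay by more than the scatter.

Compound 4 is therefore expected to give about 65 nM in this assay, with a range of 30 nM to 140 nM, which amounts to an expected step of a 1.1-fold lower number from compound 2 to compound 4 (0.03 log units; within the scatter).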

Compound 4, half-maximal inhibitory concentration: 90 nM
Beside the measured number, compound 4's estimate is 1.4-fold (0.14 log units) below it; low and high end bracket the measured number.
By their numbers in this assay, from the lowest: compounds 3, 1, 2 and 4 (each within the scatter of the next).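

In this assay cyano in place of methoxy gives a 1.3-fold higher number from compound 2 to compound 4 (0.11 log units; within the scatter) and cyano in place of hydrogen gives a 1.8-fold higher number from compound 3 to compound 4 (0.26 log units; within the scatter) while 4-cyanophenyl in place of 3-chlorophenyl gives a 1.3-fold higher number from compound 1 to compound 4 (0.11 log units; within the scatter) so a nitrile now joins methoxy, chloro and hydrogen on the phenyl ring without any step leaving the scatter. Methoxy and cyano have the same counts of heavy atoms and hydrogen-bond acceptors but differ in their atoms and in the triple bond, and this difference in the groups does not separate compound 2 and compound 4 in this assay, so the four compounds still cannot be put in an order. No measurement given here accounts for how little these groups on the ring alter the number.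

As far as these compounds go, all four compounds carry one group or none on the phenyl ring, so it stays open whether an amine, a carboxylic acid or a longer chain such as butoxy there would move the number beyond the scatter. Also open, from the compounds shown here alone, is whether a change on the shared core, and not on the phenyl ring, would do so.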